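Moving one fluorine around a tetrafluorophenyl ring

The source may hold more compounds than are shown below. What is called first, only, known or untested is meant among the compounds shown, and "the series" means these compounds.

Of the compounds shown here, three have been measured in a functional assay on CHO-K1 cells for antagonist activity at cysteinyl leukotriene receptor 1 (Homo sapiens), read by fluorescence and calcium flux, with stated times of 30 min and 1 h; a lower number here means a stronger inhibitor, a higher number a weaker inhibitor. Compound 1 `Cc1c(F)cccc1CCCCOc1ccc(C#Cc2cccc3c(CCCC(=O)O)c(C)n(CCCC(=O)O)c23)cc1` gives 1.1 nM. Compound 2 `Cc1c(CCCC(=O)O)c2cccc(/C=C/c3ccc(OCCCCc4ccccc4)cc3)c2n1CC(=O)O` gives 4.1 nM. Compound 3 `Cc1c(CCCC(=O)O)c2cccc(/C=C/c3ccc(OCCCCc4c(F)c(F)cc(F)c4F)cc3)c2n1CC(=O)O` gives 2.2 nM. Among these three numbers compound 3 stands second highest; compared with compound 2 it shows a slightly lower number, and compared with compound 1 a slightly higher one, both gaps within the scatter, so no ordering can be read from them.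

Compound 4 `Cc1c(CCCC(=O)O)c2cccc(/C=C/c3ccc(OCCCCc4c(F)cc(F)c(F)c4F)cc3)c2n1CC(=O)O` has not yet been measured. It differs from compound 3 only in the ring at the end of the chain: 2,3,4,6-tetrafluorophenyl in place of 2,3,5,6-tetrafluorophenyl on a saturated chain carbon, four bonds along the chain from an oxygen on an aromatic ring The same atoms are present in both, joined differently.

Going by the values given here, the only measured step that bears on this change is the one that introduced fluorine onto that ring: a 1.9-fold lower number from compound 2 to compound 3 (0.27 log units; within the scatter). If placing four fluorines on a bare phenyl ring barely moved the number, shifting one of those four fluorines is expected to move it even less. The estimated step of a 1.0-fold higher number from compound 3 to compound 4 (0.02 log units; within the scatter) is therefore none beyond the scatter, and compound 4 is expected to give 2.3 nM, within a range of 1 nM to 5.5 nM.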

Compound 4, half-maximal inhibitory concentration in the cysteinyl leukotriene receptor 1 assay: 1.6 nM
Estimate against measurement, compound 4: 1.4-fold (0.16 log units) above; the measured number falls inside the stated range.
By their numbers in the cysteinyl leukotriene receptor 1 assay, from the lowest: compounds 1, 4, 3 and 2 (each within the scatter of the next, the first and the last beyond it).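

In the cysteinyl leukotriene receptor 1 assay moving one fluorine gives a 1.4-fold lower number from compound 3 to compound 4 (0.14 log units; within the scatter), so the two tetrafluorophenyl isomers cannot be told apart there, yet replacing the bare phenyl with the new ring gives a 2.6-fold lower number from compound 2 to compound 4 (0.41 log units; beyond the scatter), a modest step beyond the scatter. In a physicochemical assay for permeability, using PAMPA, with a stated time of 4 h, at pH 6.2, tested at 50 uM (a lower number here means that the compound crosses the layer more slowly, a higher number that the compound crosses the layer faster), compound 3 gives 9.4 10^-6 cm/s and compound 4 gives 2.9 10^-6 cm/s. Moving one fluorine on this ring therefore separates the two compounds clearly by permeability, though not by their numbers for receptor inhibition: the measured apparent permeability of compound 3, 9.4 10^-6 cm/s, and of compound 4, 2.9 10^-6 cm/s, a 3.2-fold lower number (0.51 log units; beyond the scatter)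

The compounds shown leave open which feature of the fluorine arrangement drives this permeability gap. They also leave open whether a chlorine or a trifluoromethyl group on this ring would keep the receptor number while giving faster crossing of the layer.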